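The source may report more compounds than this note shows. Statements on the series, on what has been measured and on what is new or still open speak of the compounds shown alone.

Notes on the series, read-out an ADME assay on liver for metabolic stability, with Liver microsome (Homo sapiens) as the target, read by LC-MS, using microsomes, with a stated time of 5 h; on this read-out higher numbers stand for fast clearance and lower numbers for slow clearance. Of the compounds shown here, three carry a number so far. Compound 1 `O[C@@]1(c2ccccn2)CC[C@@H](c2ccc(C(F)(F)F)cc2)C1` gives 150 mL/min/kg, and compound 2 `O[C@H](c1ccccn1)C1(c2ccc(OC(F)(F)F)cc2)CC(F)(F)C1` gives 183 mL/min/kg, two values within the scatter of each other. Compound 3 `C[C@@]1(c2ccc(OC(F)(F)F)cc2)C[C@@](O)(c2ccccn2)CO1` gives 66.7 mL/min/kg, the lowest of the three, and its gaps to both compound 1 and compound 2 lie beyond the scatter. It is therefore the slowest-cleared compound measured in this assay, though its number is still not a small one on the range seen here.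

The next compound is compound 4 `C[C@]1(c2ccc(OC(F)(F)F)cc2)C[C@](O)(c2ccccn2)CO1`, and the change from compound 3 is purely one of configuration: the two compounds have the same atoms and bonds and differ only in configuration as drawn: 2 of 2 stereo elements differ (all stereocentres are inverted: mirror images); a stereocentre at a saturated ring carbon is drawn S in compound 3 and R in compound 4; a stereocentre at a saturated ring carbon is drawn R in compound 3 and S in compound 4. No atom or bond leaves or enters. Going by the values given here, the series holds no measured pair of mirror images, and no measured pair differs in one place only, so the data give no direct size for such a step. The working expectation in this assay is therefore no step beyond the scatter, with the direction left open and the range kept wide on both sides.

The expected change is a 1.1-fold higher number from compound 3 to compound 4 (0.05 log units; within the scatter). For compound 4 the estimated clearance is 75 mL/min/kg, with an expected range from 36 mL/min/kg to 150 mL/min/kg.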

Compound 4, clearance: 117 mL/min/kg
The estimate for compound 4 lay 1.6-fold (0.19 log units) below the measured number; measured number inside the range.
By their numbers in this assay, from the lowest: compounds 3, 4, 1 and 2 (each within the scatter of the next, the first and the last beyond it).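

Inverting every stereocentre of the shared core gives the first direct size for a purely configurational change in this assay: a 1.8-fold higher number from compound 3 to compound 4 (0.24 log units; within the scatter). With the step inside the scatter, this mirror-image pair gives no ground for preferring either form on clearance, and no order can be set between its two members. No change of atoms or bonds enters this reading, so the pair isolates configuration in a way that none of the earlier compounds could: the fact that compounds 3 and 4 differ only in the configuration as drawn

The compounds shown leave open what inverting one stereocentre at a time would do, since both are inverted together here, and whether a step of this size holds for any core other than this one. As far as these compounds go, it also remains open whether the same small step would be seen with an amine or a carboxylic acid on the shared core, and the data give no account of where in these compounds clearance arises.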